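The chain aryl group returns in compound 4

A few compounds are considered here, and "the series" means these few. Any claim that something is new, unique, unknown or untested is made for them only; others in the source may bear on it.

Measured compounds:
Compound 1 `CC(=O)OC/C(=C\c1ccc(Cl)cc1Cl)C(=O)c1ccccc1` gives 97000 nM in a functional assay on A549 cells (Homo sapiens) for inhibition, read by XTT assay, with a stated time of 48 h; on this read-out lower numbers stand for stronger inhibition and higher numbers for weaker inhibition.
Compound 2 `CCC(/C=C(\COC(C)=O)C(=O)c1ccc(OC)cc1)CC` gives only a limit in this assay, namely > 100000 nM.
Compound 3 `CCC(/C=C(\COC(=O)c1ccccc1)C(=O)c1ccc(OC)cc1)CC` likewise gives only a limit in this assay, namely > 100000 nM.

Compound 3 therefore stands not at a number but at the limit of this assay. Compound 2 sits at the same limit, so the step from compound 2 to compound 3 a step that the two limits leave unreadable from compound 2 to compound 3 cannot be read in size; this follows from the limit of > 100000 nM in this assay, at which 2 of the 3 values shown sit.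

Compound 4 `COc1ccc(C(=O)/C(=C/c2ccccc2Cl)COC(=O)c2ccccc2)cc1` differs from compound 3 by 2-chlorophenyl in place of pentan-3-yl on a double-bonded chain carbon bound to a double-bonded chain carbon. Going by the values given here, no measured step touches this group on the double-bonded chain carbon, so none bears directly on the change. Among the compounds with values here, the only measured compound with an aryl ring on the double-bonded chain carbon is compound 1, which gives a number, 97000 nM, in this assay, though compound 1 also differs from compound 4 in its other groups.

On that slender basis compound 4 is expected to move off the limit by a modest step of an at least 1.4-fold lower number from compound 3 to compound 4 (0.15 log units; that floor lies within the scatter). The estimate for compound 4 is 70000 nM, with a range from 25000 nM to 150000 nM.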

Compound 4, half-maximal inhibitory concentration: 20100 nM
Compound 4: the middle estimate sits 3.5-fold (0.54 log units) above what was measured; the whole stated range lies above it.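

Going by these compounds alone, this is the first readable change at this place. On a double-bonded chain carbon bound to a double-bonded chain carbon, 2-chlorophenyl in place of pentan-3-yl gives, in this assay, an at least 4.9-fold lower number from compound 3 to compound 4 (0.69 log units; beyond the scatter), so this single swap, with the rest of the molecule unchanged, brings a measurable inhibition beyond the usual scatter. The true step may be larger still, since compound 3 has no number and the printed size is only a floor: the limit of > 100000 nM in this assay, at which 2 of the 4 values shown sit.

The compounds shown leave open whether this gain needs the chlorine or the aromatic ring itself, which a plain phenyl, a pyridine ring or a cyclohexyl ring at this place would separate. As far as these compounds go, the effect of phenyl in place of methyl on the ester carbonyl also stays open, as that step cannot be read at the limit.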